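Methoxy variant of a urea-linked pyrazole series

The source may hold more compounds than are shown below. What is called first, only, known or untested is meant among the compounds shown, and "the series" means these compounds.

Measured so far:
compound 1 `O=C(Nc1cccc(-n2cc(-c3ccncc3)c(-c3cc(O)cc(Cl)c3)n2)c1)Nc1ccc(Cl)c(C(F)(F)F)c1`: 96%
compound 2 `O=C(Nc1cccc(-n2cc(-c3ccncc3)c(-c3cc(O)cc(Cl)c3)n2)c1)Nc1ccc(Cl)c(Cl)c1`: 96%

In a functional assay on NCI-H23 cells (Homo sapiens) for inhibition, read by sulforhodamine B assay, with a stated time of 48 h, tested at 1 uM (on this read-out higher numbers stand for a weaker effect at the one concentration tested and lower numbers for a stronger effect), compound 1 gives 96% and compound 2 gives 96%; the step of no change at the digits printed from compound 1 to compound 2 (within the scatter) is within the scatter, so compound 1 stands level with compound 2 on these numbers. Compound 3 `COc1cc(Cl)cc(-c2nn(-c3cccc(NC(=O)Nc4ccc(Cl)c(C(F)(F)F)c4)c3)cc2-c2ccncc2)c1` is not yet measured. It differs from compound 1 by methyl in place of hydrogen on an oxygen on an aromatic ring. For the measured compounds named here, no measured step touches this oxygen, so the one step available, no change at the digits printed from compound 1 to compound 2 (within the scatter), bears only indirectly, showing that a change at the far aromatic ring moved nothing. No step beyond the scatter is therefore expected in this assay; the step of a number 2 percentage points lower from compound 1 to compound 3 (within the scatter) is expected. Compound 3 is estimated at 94%, with a range from 80% to 105%.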

Compound 3, a percentage reported as activity, at one concentration (the size of the read-out at that concentration, not a potency): 60%
Compound 3: middle estimate off by 34 percentage points, on the high side; measured number outside the range, below it.
By their numbers in this assay, from the lowest: compound 3; then compounds 1 and 2 (each within the scatter of the next).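

In this assay hydroxy to methoxy on the 3-chloro-5-hydroxyphenyl reads as a number 36 percentage points lower from compound 1 to compound 3 (beyond the scatter) and so as a stronger effect at the one concentration tested. For the compounds shown here, this oxygen is therefore a place where one added methyl moves the read-out, whereas the only earlier step, at the far aromatic ring, stayed within the scatter. No measurement at hand accounts for the shift. Open, as far as these compounds go, is whether ethoxy, a longer chain on this oxygen, or an amine in its place goes further, and whether the methoxy effect holds with the far-ring chloro of compound 2.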